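The source may hold more compounds than are shown below. What is called first, only, known or untested is meant among the compounds shown, and "the series" means these compounds.

Compound 2 `Cc1noc(C)c1-c1cnc(N)c(Oc2ccc(C(=O)Nc3ccc(Cl)cn3)cc2)n1` carries a 5-chloropyridin-2-yl group on its amide nitrogen. In a functional assay on LoVo cells (Homo sapiens) for inhibition, read by MTT assay, with a stated time of 72 h (a higher number here means a weaker inhibitor, a lower number a stronger inhibitor), compound 2 gives 9180 nM. Compound 3 `Cc1noc(C)c1-c1cnc(N)c(Oc2ccc(C(=O)Nc3ncccc3Cl)cc2)n1`, with a 3-chloropyridin-2-yl group in the same place, gives 14800 nM in this assay; the two stand together, since a 1.6-fold higher number from compound 2 to compound 3 (0.21 log units; within the scatter) lies within the scatter. Compound 1 `Cc1noc(C)c1-c1cnc(N)c(Oc2ccc(C(=O)NC3CC3)cc2)n1`, which has a cyclopropyl group on that nitrogen, reaches only the limit of this assay at > 100000 nM. Measured from that limit, the change to the first pyridyl amide is an at least 10-fold lower number from compound 1 to compound 2 (1.03 log units; beyond the scatter) and to the second at least 6.7-fold lower number from compound 1 to compound 3 (0.82 log units; beyond the scatter). Compound 4 `Cn1cc(-c2cnc(N)c(Oc3ccc(C(=O)Nc4ccc(Cl)cn4)cc3)n2)cn1` keeps the amide side of compound 2 unchanged and differs from it at the other end of the molecule: 1-methyl-1H-pyrazol-4-yl in place of 3,5-dimethyl-1,2-oxazol-4-yl on an aromatic carbon. None of the three measured steps touches this position; all of them alter only the group on the amide nitrogen. Within the data shown here, no measured step therefore speaks for a change in this assay, and a step of a 1.0-fold lower number from compound 2 to compound 4 (0.01 log units; within the scatter) is expected, with a wide range, as no measured step covers this change. Compound 4 is estimated at 9000 nM, between 3000 nM and 30000 nM.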

Compound 4, half-maximal inhibitory concentration: 6160 nM
For compound 4 the middle estimate is 1.5-fold (0.16 log units) above the measured one, within the range that was stated.
By their numbers in this assay, from the lowest: compounds 4, 2 and 3 (each within the scatter of the next, the first and the last beyond it). At a limit, above all of these: compound 1.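

Until now every measured step altered the group on the amide nitrogen. Among these compounds, this is the first measured step at the other end of the molecule: in this assay, 1-methyl-1H-pyrazol-4-yl in place of 3,5-dimethyl-1,2-oxazol-4-yl gives a 1.5-fold lower number from compound 2 to compound 4 (0.17 log units; within the scatter). With the 5-chloropyridin-2-yl amide held fixed, one five-membered aromatic ring with 2 hetero atoms can therefore stand in for another on this aromatic carbon, and the two compounds read alike; nothing measured here bears on why.

Going by these compounds, what an amine, a carboxylic acid or a plain phenyl ring would give at this position stays open. So does whether the same exchange reads alike on the cyclopropyl amide of compound 1 or the 3-chloropyridin-2-yl amide of compound 3.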